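The source may report more compounds than this note shows. Statements on the series, on what has been measured and on what is new or still open speak of the compounds shown alone.

Three compounds have been measured in an assay on HEK293 cells for displacement of a labelled ligand from 5-hydroxytryptamine receptor 6 (Homo sapiens), read by scintillation counting, with a stated time of 1 h; a higher number here means a weaker inhibitor, a lower number a stronger inhibitor:

Compound 1 `O=S(=O)(c1cccc2ncccc12)N1CCC(CCN2CCN(c3ccccc3)CC2)CC1`: 6710 nM
Compound 2 `O=S(=O)(c1cccc2ncccc12)N1CCC(CCN2CCN(c3ccc(Cl)cc3)CC2)CC1`: 1020 nM
Compound 3 `O=S(=O)(c1cncc2ccccc12)N1CCC(CCN2CCN(c3cccc(Cl)c3)CC2)CC1`: 1190 nM

Compound 2 gives the lowest number of the three in this assay. Its nearest neighbour is compound 3, whose number lies within the usual scatter of it, so the two cannot be ordered; compound 1 lies further off, the step of a 6.6-fold lower number from compound 1 to compound 2 (0.82 log units; beyond the scatter) being beyond the scatter. Compound 4 `O=S(=O)(c1cccc2ncccc12)N1CCC(CCN2CCN(c3cccc(Cl)c3Cl)CC2)CC1` has not yet been measured. It differs from compound 2 in one place: 2,3-dichlorophenyl in place of 4-chlorophenyl on an amine nitrogen in a ring. Among the compounds with values here, the only measured step that bears on this change is a 6.6-fold lower number from compound 1 to compound 2 (0.82 log units; beyond the scatter), where a single chloro added to the aromatic ring on the amine nitrogen brought a modest drop in the number. Within the data shown here, no measured pair shows what a second chloro does, nor what shifting the chloro does; compound 3 differs from compound 2 in more than one place, and its number is within the scatter of compound 2. The step of a 1.5-fold lower number from compound 2 to compound 4 (0.16 log units; within the scatter) is therefore expected to be small, possibly within the scatter, leaning toward a lower number because a 6.6-fold lower number from compound 1 to compound 2 (0.82 log units; beyond the scatter) went that way on adding chlorine to this ring. The estimate for compound 4 in this assay is 700 nM, in the range 200 nM to 2500 nM.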

Compound 4, inhibition constant: 401 nM
The estimate for compound 4 lay 1.7-fold (0.24 log units) above the measured number; low and high end bracket the measured number.
By their numbers in this assay, from the lowest: compound 4; then compounds 2 and 3 (each within the scatter of the next); then compound 1.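

In this assay, replacing 4-chlorophenyl with 2,3-dichlorophenyl on the amine nitrogen in the ring gives a 2.5-fold lower number from compound 2 to compound 4 (0.41 log units; beyond the scatter), which shows that a single chloro on this ring did not exhaust what a change at this position can do to the number. Measured against the unsubstituted phenyl, the same position gives a 17-fold lower number from compound 1 to compound 4 (1.22 log units; beyond the scatter), a large step that runs in the same direction as the earlier step from adding one chloro, so both chlorinated rings shown on this core give lower numbers than phenyl. Nothing available explains why the number falls with this change.

This single change alters both the number of chlorines and their places on the ring, so the share of each cannot be separated without a compound such as the 2-chlorophenyl analogue on the core of compound 1. On these data alone, it also remains open whether chlorine itself matters or whether other groups on this ring, such as 2,3-dimethylphenyl or 2-methoxyphenyl, would move the number in the same way.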